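A few compounds are considered here, and "the series" means these few. Any claim that something is new, unique, unknown or untested is made for them only; others in the source may bear on it.

Compound 1 `CCN(CC)CN1C(=O)/C(=N\c2nc3ccc(C)cc3s2)c2ccccc21` gives 27500 nM in an ADME assay on 184B5 cells (Homo sapiens) for cytotoxicity, read by sulforhodamine B assay, with a stated time of 48 h; a lower number here means a stronger inhibitor of growth, a higher number a weaker inhibitor of growth. Compound 2 `CCN(CC)CN1C(=O)/C(=N\c2nc3ccc(C)cc3s2)c2c(Br)cccc21` gives 34300 nM in this assay. Compound 3 `O=C1C(=O)N(CN(c2ccccc2)c2ccccc2)c2cccc(Cl)c21` gives 96800 nM in this assay.

Compound 1 shows the lowest number of the three. Compound 2 sits nearest to it, and the step from compound 1 to compound 2 a 1.2-fold higher number from compound 1 to compound 2 (0.10 log units; within the scatter) lies within the scatter, so the two cannot be ranked. Compound 3 stands furthest from compound 1, with a gap that goes beyond the scatter.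

The next compound to be measured, compound 4 `Cc1ccc2nc(/N=C3\C(=O)N(CN(C)C)c4ccccc43)sc2c1`, keeps the shared core of compound 1 and differs at one place: dimethylamino in place of diethylamino on a saturated chain carbon bound to an amide-type nitrogen in a ring.

Going by the values given here, no measured pair bears directly on this change. Among the compounds with values here, the only step available, from compound 1 to compound 2 a 1.2-fold higher number from compound 1 to compound 2 (0.10 log units; within the scatter), concerns a bromo group on an aromatic carbon, not the amine on the chain carbon, and even that change stayed within the scatter. Within the data shown here, with no step of the matching kind, the expectation for compound 4 in this assay rests on the closeness of the two amines named in the change, and the expected step from compound 1 to compound 4 no change at the digits printed from compound 1 to compound 4 (within the scatter) is none beyond the scatter. Compound 4 is therefore estimated at 27500 nM, with a range from 12000 nM to 62000 nM.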

Compound 4, concentration for 50% growth inhibition: 15600 nM
Beside the measured number, compound 4's estimate is 1.8-fold (0.25 log units) above it, and the stated range covers the measured number.
By their numbers in this assay, from the lowest: compounds 4, 1 and 2 (each within the scatter of the next, the first and the last beyond it); then compound 3.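

Going by these compounds alone, this is the first measured change at the amine on the saturated chain carbon bound to an amide-type nitrogen in a ring. In this assay, the step of a 1.8-fold lower number from compound 1 to compound 4 (0.25 log units; within the scatter) stays inside the scatter, so the two compounds cannot be ranked, and trimming diethylamino with its 5 heavy atoms to dimethylamino with its 3 gives no readable difference for this pair. No measurement is available that would account for the size of this step, so the result stands here as a number without an explanation.

From the compounds shown here alone, one pair cannot show how this position responds to larger changes, so it remains open whether a ring amine such as piperidine or morpholine, or a longer chain in place of (dimethylamino)methyl, would move the number beyond the scatter. Going by these compounds, it also remains open whether dimethylamino in place of diethylamino would give a similar step on compound 2, which carries the bromo group on an aromatic carbon.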